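Trading a Pyridyl Ring for a Bromine Atom

A few compounds are considered here, and "the series" means these few. Any claim that something is new, unique, unknown or untested is made for them only; others in the source may bear on it.

Of the compounds shown here, two have been tested in an assay on CHO cells for displacement of a labelled ligand from adenosine receptor A1 (Homo sapiens), read by scintillation counting, tested at 10 uM; on this read-out lower numbers stand for less inhibition and higher numbers for more inhibition at the one concentration tested (going by the name of the read-out). Compound 1, with the structure `CC(C)(C)Cc1c(-c2cccnc2)sc(N)c1C(=O)c1ccc(Cl)cc1`, gives 1% in this assay. Compound 2, with the structure `Cc1ccc(C(=O)c2c(CC(C)(C)C)csc2N)cc1`, is a smaller relative; in this assay compound 2 gives 1%. Compound 1 thus stands level with compound 2 at the digits shown, and neither compound displaces much of the labelled ligand at the concentration tested.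

Compound 3, with the structure `CC(C)(C)Cc1c(Br)sc(N)c1C(=O)c1ccc(Cl)cc1`, has not yet been measured in this assay. It differs from compound 1 in a single place: bromo in place of pyridin-3-yl on an aromatic carbon. A six-atom ring containing one nitrogen leaves and a single bromine atom enters, while the rest of the molecule stays as in compound 1.

Because compound 1 shows only 1% and compound 2 likewise only 1%, there is no sign in these two compounds that this part of the molecule drives inhibition. The step of a number 2 percentage points higher from compound 1 to compound 3 (within the scatter) is therefore expected to be none beyond the scatter. Compound 3 is estimated to give 3%, within a range from -6% to 15%.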

Compound 3, a percentage reported as inhibition, at one concentration (the size of the read-out at that concentration, not a potency): 1%
Beside the measured number, compound 3's estimate is 2 percentage points above it; low and high end bracket the measured number.
By their numbers in this assay, from the lowest: compounds 1, 2 and 3 (each within the scatter of the next).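

In this assay, replacing pyridin-3-yl with bromo on the aromatic carbon next to the ring sulfur gives no change at the digits printed from compound 1 to compound 3 (within the scatter). Going by these compounds alone, this is the first direct comparison at this position: a six-membered aromatic ring with 1 hetero atom gives way to a single bromine atom, and the read-out does not separate the two compounds. Nothing in the data explains this result, and with compound 1 already at 1%, the comparison cannot show whether either group matters for displacing the labelled ligand.

The compounds shown leave open whether any group on this carbon, such as an aminomethyl group, a carboxylic acid or a longer chain, would give a clearly higher reading in this assay. They also leave open whether pyridin-3-yl and bromo would still read alike on a relative of compound 1 with a different group in place of the neopentyl group, one that shows clear inhibition at the concentration tested.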